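The compounds below may be only part of what the source reports. "The series", "measured", "known", "first", "only" and "open" are said of these compounds alone.

Measured so far:

Compound 1, `C=C(C)C(=O)c1ccc(OCc2nc(-c3ccc(F)cc3)no2)cc1C`: 4600 nM
Compound 2, `C=C(C)C(=O)c1ccc(OCc2nc(-c3ccc(C(F)(F)F)cc3)no2)cc1C`: 3200 nM
Compound 3, `C=C(CC)C(=O)c1ccc(OCc2nc(-c3ccc(F)cc3)no2)c(Cl)c1Cl`: 1700 nM

All three were tested in a functional assay on HL-60 cells (Homo sapiens) for inhibition; on this read-out lower numbers stand for stronger inhibition of growth and higher numbers for weaker inhibition of growth. Compound 1 and compound 2 share one core and differ in a single place: trifluoromethyl in place of fluoro on an aromatic carbon. The step that goes with this change is a 1.4-fold lower number from compound 1 to compound 2 (0.16 log units; within the scatter). Compound 3 is built on a different core; the difference between the two cores is not broken down here. In this assay compound 3 gives 1700 nM, and compound 2 gives 3200 nM, two numbers that sit within the usual scatter of each other.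

Compound 4, `C=C(CC)C(=O)c1ccc(OCc2nc(-c3ccc(C(F)(F)F)cc3)no2)c(Cl)c1Cl`, has not been measured. It relates to compound 3 as compound 2 relates to compound 1: trifluoromethyl in place of fluoro on an aromatic carbon. The place of the change is described in the same words for both pairs, so this is the same change on a different core. Taking the measured step as the only guide, the change from compound 3 to compound 4 is expected to give a 1.4-fold lower number from compound 3 to compound 4 (0.15 log units; within the scatter), resting on the fact that the change from compound 1 to compound 2 gave a 1.4-fold lower number from compound 1 to compound 2 (0.16 log units; within the scatter). Compound 4 is therefore estimated at 1200 nM in this assay, with a likely range from 500 nM to 3000 nM.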

Compound 4, concentration for 50% growth inhibition: 1100 nM
Beside the measured number, compound 4's estimate is 1.1-fold (0.04 log units) above it, and the stated range covers the measured number.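

In this assay, the new step is a 1.5-fold lower number from compound 3 to compound 4 (0.19 log units; within the scatter), and it can be set beside the earlier step on the other core: the same change on two cores in this assay, a 1.4-fold lower number (0.16 log units; within the scatter) from compound 1 to compound 2 and a 1.5-fold lower number (0.19 log units; within the scatter) from compound 3 to compound 4, 1.1-fold (0.03 log units) apart, within the scatter of two such steps. The change from 4-fluorophenyl to 4-(trifluoromethyl)phenyl therefore gave matching results on these two cores, and here the step read on one core was a fair guide to the step on the other. Each step lies within the scatter, however, so this agreement does not show that trifluoromethyl and fluoro truly differ in this assay, and two cores cannot establish that the match holds across the whole series.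

Still open, going by these compounds, is whether a different group in that same place, such as a nitrile, an amine or a carboxylic acid, would give a step beyond the scatter. Also open is which of the differences between the two cores matters for growth inhibition, as the compounds shown do not separate them one at a time.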